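Cytotoxicity in murine cells across a shared pyrimidine-amine core

This account rests on a few compounds, and the source may have more. Where it says the series, first, only, none or still open, it means among the compounds named here.

Compound 1, `CC(C)Cn1cc(-c2cc(Nc3ccc(OC(F)(F)F)cc3)ncn2)cn1`, gives in an ADME assay on BaF3 cells (Mus musculus) for cytotoxicity (a higher number here means that more compound is needed for the effect, a lower number that less compound is needed), a value of > 10000 nM, which is a limit of the assay.
Compound 2, `Nc1cccc(-c2cc(Nc3ccc(OC(F)(F)F)cc3)ncn2)c1`, gives in this assay a value of > 10000 nM, again a limit of the assay.
Compound 3, `FC(F)(F)Oc1ccc(Nc2cc(-c3cccc4[nH]ccc34)ncn2)cc1`, gives in this assay a value of 3790 nM.

Among the measured compounds shown here, compound 3 holds the only measured number among the three; the other two sit at the limit of > 10000 nM in this assay, at which 2 of the 3 values shown sit. The step of an at least 2.6-fold lower number from compound 1 to compound 3 (0.42 log units; beyond the scatter) and the step of an at least 2.6-fold lower number from compound 2 to compound 3 (0.42 log units; beyond the scatter) both read as at least modest, while the step that the two limits leave unreadable from compound 1 to compound 2 cannot be sized. Compound 4, `FC(F)(F)Oc1ccc(Nc2cc(-n3ccnc3)ncn2)cc1`, is not yet measured. It differs from compound 3 in one place: 1H-imidazol-1-yl in place of 1H-indol-4-yl on an aromatic carbon. The two steps that lead to compound 3 show that the 1H-indol-4-yl group goes with the lowest number seen, so removing it is expected to raise the number in this assay, perhaps back toward the limit. For compound 4 an estimated step of a 2.4-fold higher number from compound 3 to compound 4 (0.38 log units; beyond the scatter) is expected. Compound 4 is therefore estimated at 9000 nM, within 3000 nM to 30000 nM.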

Compound 4, half-maximal effective concentration: > 10000 nM
Compound 4 was reported as a limit; the forecaster's own chance of this, stated with the estimate: 55%; at least 1.1-fold (0.04 log units) between middle value and limit.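

Replacing the 1H-indol-4-yl group with 1H-imidazol-1-yl on this aromatic carbon gives an at least 2.6-fold higher number from compound 3 to compound 4 (0.42 log units; beyond the scatter) in this assay. Among the four compounds, the one number below the limit now goes with 1H-indol-4-yl alone, set against three other groups at this position: the limit of > 10000 nM in this assay, at which 3 of the 4 values shown sit. The steps that join compound 1, compound 2 and compound 4 to one another cannot be read, since each links two limits.

The compounds shown leave open whether the lower number depends on the two rings of 1H-indol-4-yl or on its hydrogen-bond donor, a question that a benzofuran-4-yl group at this position would address. From the compounds shown here alone, whether a 1H-indol-5-yl group, attached through a different ring carbon, would keep the lower number also remains open.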